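The compounds below may be only part of what the source reports. "The series", "measured", "known", "first", "only" and "open" are said of these compounds alone.

Measured compounds:
compound 1 `O=C(Nc1cccc(-n2cc(-c3ccncc3)c(-c3cc(O)cc(Cl)c3)n2)c1)Nc1ccc(Cl)c(Cl)c1`: 90%
compound 2 `COc1cc(Cl)cc(-c2nn(-c3cccc(NC(=O)Nc4cc(C(F)(F)F)cc(C(F)(F)F)c4)c3)cc2-c2ccncc2)c1`: 92%

Both measured compounds share a core and differ in the urea aryl part and in the substituent on the oxygen of the chlorophenyl ring. In a functional assay on 786-0 cells (Homo sapiens) for inhibition, read by sulforhodamine B assay, with a stated time of 48 h, tested at 0.1 uM (a lower number here means a stronger effect, a higher number a weaker effect of the compound at the concentration tested), compound 1 gives 90%, which is the lower of the two numbers shown; in this assay compound 2 gives 92%, and the gap between the two lies within the scatter, so the two cannot be told apart on these data. Both numbers are high, meaning a weak effect at the concentration tested.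

Compound 3 `COc1cc(Cl)cc(-c2nn(-c3cccc(NC(=O)Nc4ccc(Cl)c(Cl)c4)c3)cc2-c2ccncc2)c1` is not yet measured. It differs from compound 1 by methyl in place of hydrogen on an oxygen on an aromatic ring. Among the compounds with values here, no step between measured compounds isolates this change. Since compound 2 already carries methoxy at this place and gives 92%, little movement is expected. The step of no change at the digits printed from compound 1 to compound 3 (within the scatter) is expected to stay within the scatter. Compound 3 is estimated at 90%, with a range from 78% to 100%.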

Compound 3, a percentage reported as activity, at one concentration (the size of the read-out at that concentration, not a potency): 98%
Compound 3: middle estimate off by 8 percentage points, on the low side; the range from low to high includes it.
By their numbers in this assay, from the lowest: compounds 1, 2 and 3 (each within the scatter of the next).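

Within the data shown here, with the urea aryl part held constant, hydroxy to methoxy on the 3-chloro-5-hydroxyphenyl ring gives a number 8 percentage points higher from compound 1 to compound 3 (within the scatter) in this assay, the first reading of this change alone, as compound 1 and compound 2 differ in more than one place. At this one concentration, the hydroxy and methoxy compounds cannot be told apart, so the hydrogen on this oxygen shows no measurable role here. No supporting data bear on the reason for this outcome.

Going by these compounds, whether an amine in place of the hydroxy, or a longer chain such as ethoxy on this oxygen, would give a clearly lower number in this assay remains open. Also open, on these data alone, is whether the same step would read alike with the urea aryl part of compound 2.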